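One added methyl on a short ether chain

The compounds below may be only part of what the source reports. "The series", "measured", "known", "first", "only" and "open" are said of these compounds alone.

Measured in a functional assay on a cell-free system (plasma, Homo sapiens) for inhibition, with Plasma (Rattus norvegicus) as the target; a lower number here means a stronger inhibitor, a higher number a weaker inhibitor:
Compound 1 `Cc1c(OCc2ccccc2)ccc2c(N3CCNCC3)cc(=O)oc12`: 1900 nM
Compound 2 `COCOc1ccc2c(N3CCNCC3)cc(=O)oc2c1C`: 2300 nM

Compound 2, at 2300 nM, lies within the scatter of compound 1, so neither stands apart on these numbers. Compound 3 `CCOCOc1ccc2c(N3CCNCC3)cc(=O)oc2c1C` differs from compound 2 by methyl in place of hydrogen on a saturated chain carbon bound to an oxygen on a saturated carbon, which reads as methoxymethyl to ethoxymethyl. Within the data shown here, the only measured step that bears on this change is a 1.2-fold higher number from compound 1 to compound 2 (0.08 log units; within the scatter), and it replaces a whole phenyl rather than adding one methyl. No step beyond the scatter is therefore expected in this assay. The expected step is a 1.0-fold lower number from compound 2 to compound 3 (0.02 log units; within the scatter). Compound 3 is estimated at 2200 nM, with an expected range from 1100 nM to 4500 nM.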

Compound 3, half-maximal inhibitory concentration: 1800 nM
Compound 3: the middle estimate sits 1.2-fold (0.09 log units) above what was measured, within the range that was stated.
By their numbers in this assay, from the lowest: compounds 3, 1 and 2 (each within the scatter of the next).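

In this assay one added methyl on this saturated chain carbon can now be read directly: methoxymethyl to ethoxymethyl gives a 1.3-fold lower number from compound 2 to compound 3 (0.11 log units; within the scatter) and thus no step beyond the scatter. Ethoxy in place of phenyl gives a 1.1-fold lower number from compound 1 to compound 3 (0.02 log units; within the scatter) as well, so neither the small change nor the larger one separates these compounds. No evidence is available that bears on this result.

On these data alone, whether a longer chain such as propoxymethyl, or an amine at the end of the chain, would give a step beyond the scatter remains open.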